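A Dimethylphenyl Group Replaces a Trifluoromethylphenyl Group

The compounds below may be only part of what the source reports. "The series", "measured", "known", "first", "only" and "open" are said of these compounds alone.

In a functional assay on HeLa cells (Homo sapiens) for antiproliferative activity, read by spectrophotometry, with a stated time of 2 days (on this read-out higher numbers stand for weaker inhibition of growth and lower numbers for stronger inhibition of growth), compound 1 `COc1ccc(Nc2ncc(C(F)(F)F)c(N3Cc4cccc(N(C)S(C)(=O)=O)c4C3)n2)cc1C(F)(F)F` gives 14000 nM and compound 2 `COc1ccc(C(F)(F)F)cc1Nc1ncc(C(F)(F)F)c(N2Cc3cccc(N(C)S(C)(=O)=O)c3C2)n1` gives 17200 nM. Between these two the read-out barely moves, with a 1.2-fold higher number from compound 1 to compound 2 (0.09 log units; within the scatter). Compound 3 `CN(c1cccc2c1CN(c1nc(Nc3ccc(C(F)(F)F)cc3)ncc1C(F)(F)F)C2)S(C)(=O)=O` has no number, only a limit of the assay, > 30000 nM.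

Compound 4 `Cc1ccc(Nc2ncc(C(F)(F)F)c(N3Cc4cccc(N(C)S(C)(=O)=O)c4C3)n2)c(C)c1` carries 2,4-dimethylphenyl in place of 4-(trifluoromethyl)phenyl on a nitrogen on an aromatic ring. Two measured steps change the group at this same place: an at least 2.1-fold higher number from compound 1 to compound 3 (0.33 log units; beyond the scatter), and an at least 1.7-fold higher number from compound 2 to compound 3 (0.24 log units; that floor lies within the scatter). Both are small floors rather than true sizes, and neither involves a dimethylphenyl group. With compound 1 at 14000 nM and compound 2 at 17200 nM in this assay, a different substituted phenyl could return a number, so only a modest move toward a lower number is expected. Compound 4 may equally remain at the limit. The expected change is an at least 1.5-fold lower number from compound 3 to compound 4 (0.17 log units; that floor lies within the scatter). For compound 4 the estimated value is 20000 nM. The estimated range for compound 4 runs from 9000 nM to 30000 nM.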

Compound 4, concentration for 50% growth inhibition: 10600 nM
Compound 4: the middle estimate sits 1.9-fold (0.28 log units) above what was measured; low and high end bracket the measured number.
By their numbers in this assay, from the lowest: compounds 4, 1 and 2 (each within the scatter of the next). At a limit, above all of these: compound 3.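

In this assay, 2,4-dimethylphenyl in place of 4-(trifluoromethyl)phenyl on a nitrogen on an aromatic ring returns a measured number, with an at least 2.8-fold lower number from compound 3 to compound 4 (0.45 log units; beyond the scatter). On these data alone, compound 3 has only a limit of the assay, > 30000 nM, so that step is a floor and its true size stays unknown: the limit of > 30000 nM in this assay, at which 1 of the 4 values shown sits. The position also gives a measured number with no trifluoromethyl group on this phenyl ring, yet a 1.6-fold lower number from compound 2 to compound 4 (0.21 log units; within the scatter) and a 1.3-fold lower number from compound 1 to compound 4 (0.12 log units; within the scatter) leave compound 4 level with compound 1 and compound 2.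

The compounds shown leave open whether one methyl group alone would give the same result, as only the 2,4-dimethylphenyl pair is shown. They also leave open how an amine or a carboxylic acid on this phenyl ring would read in this assay.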